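Chloro entry on the shared five-membered core: solubility notes

The source may hold more compounds than are shown below. What is called first, only, known or untested is meant among the compounds shown, and "the series" means these compounds.

Measured so far:
- compound 1, `CCOc1ccc(-c2csc(Nc3ccc(Cl)cn3)n2)nc1`; in a physicochemical assay for solubility, in phosphate buffer, with a stated time of 2 h, at pH 7.4 (on this read-out higher numbers stand for higher solubility and lower numbers for lower solubility), compound 1 gives < 10000 nM, a limit.
- compound 2, `CCOc1ccc(-c2nc(Nc3ccc(Cl)cn3)sc2Cl)nc1`; compound 2 gives < 10000 nM, also a limit.
- compound 3, `Clc1ccc(Nc2nc(-c3ncccn3)cs2)nc1`; compound 3 gives 20000 nM, the only number in this set.

The step that the two limits leave unreadable from compound 1 to compound 2 is chloro in place of hydrogen on an aromatic carbon; its size cannot be read because the limit of < 10000 nM in this assay, at which 2 of the 3 values shown sit, holds both ends. The difference between the cores of compound 1 and compound 3 is not broken down here.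

Compound 4, `Clc1ccc(Nc2nc(-c3ncccn3)c(Cl)s2)nc1`, is not yet measured. It carries chloro in place of hydrogen on an aromatic carbon. This is the same kind of change as that from compound 1 to compound 2, not the same: there the carbon sits next to the ring atom that bears a group of 9 heavy atoms, here next to the ring atom that bears a pyrimidin-2-yl group (6 heavy atoms).

The expected step of a 1.7-fold lower number from compound 3 to compound 4 (0.22 log units; within the scatter) rests on compound 3 at 20000 nM and on an earlier step of unknown size, so it is held near neutral. Compound 4 is estimated at 12000 nM, expected between 4000 nM and 30000 nM.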

Compound 4, solubility: < 10000 nM
Compound 4 gave a limit, no number (the forecaster's own chance of this, stated with the estimate: 40%); middle value at least 1.2-fold (0.07 log units) away from the limit.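

In this assay compound 4 gives < 10000 nM, a limit and not a number. On the core of compound 3, chloro in place of hydrogen on an aromatic carbon therefore gives an at least 2.0-fold lower number from compound 3 to compound 4 (0.30 log units; that floor lies within the scatter), so only a floor is known, not the size of the step. The same change on the core of compound 1 cannot be read, and whether the step carries over from one core to the other in size stays unknown: the limit of < 10000 nM in this assay, at which 3 of the 4 values shown sit.

The compounds shown leave open how either core would read in this assay with an amine or a carboxylic acid on that carbon in place of the chloro. They also leave open where compounds 1, 2 and 4 truly lie under their limits.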